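The source may hold more compounds than are shown below. What is called first, only, known or untested is meant among the compounds shown, and "the series" means these compounds.

Compound 1 `N#CCNC(=O)[C@@H]1C[C@@H](S(=O)(=O)c2ccccc2Cl)C[C@H]1C(=O)N1CCOCC1` and compound 2 `CC1CCN(C(=O)[C@@H]2C[C@H](S(=O)(=O)c3ccccc3)C[C@H]2C(=O)NC2(C#N)CC2)CC1` share a core bearing a nitrile-containing amide and an arylsulfonyl group. In an assay on isolated protein for inhibition of cathepsin S (Homo sapiens), read by fluorescence, with a stated time of 20 min (on this read-out lower numbers stand for stronger inhibition and higher numbers for weaker inhibition), compound 1 gives 0.5 nM, and in this assay compound 2 gives 0.5 nM, so the two stand level within the scatter. Compound 3 `CN(C)C(=O)[C@@H]1C[C@H](S(=O)(=O)c2ccccc2)C[C@H]1C(=O)NC1(C#N)CC1` carries dimethylamino in place of 4-methylpiperidin-1-yl on a carbonyl carbon. With no measured step of this kind among these compounds, the direction rests on the smaller group alone, and a modest loss is expected, shown by a 4.0-fold higher number from compound 2 to compound 3 (0.60 log units; beyond the scatter). The estimate for compound 3 in this assay is therefore 2 nM, expected between 0.5 nM and 8 nM.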

Compound 3, half-maximal inhibitory concentration: 6 nM
For compound 3 the middle estimate is 3.0-fold (0.48 log units) below the measured one; the measured number falls inside the stated range.
By their numbers in this assay, from the lowest: compounds 1 and 2 (each within the scatter of the next); then compound 3.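

In this assay, dimethylamino in place of 4-methylpiperidin-1-yl on the carbonyl carbon gives a 12-fold higher number from compound 2 to compound 3 (1.08 log units; beyond the scatter) and this large step shows that the group at this position matters for the read-out. The earlier compounds shown here offered no such step, and here the lower number goes with the larger, ring-bearing group. Nothing in the data explains the step. Going by these compounds, what stays open is whether the ring itself or the number of heavy atoms counts. Unsubstituted piperidin-1-yl or open-chain diethylamino at this position would separate the two.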